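Amine Swap on a Carbamate Chain: Toward Compound 3

The source may hold more compounds than are shown below. What is called first, only, known or untested is meant among the compounds shown, and "the series" means these compounds.

Measured so far:
compound 1, `CCCCCCCCCCCCCC[C@H](OCOC)[C@H](CN(CCCC)CCCC)NC(=O)OC(C)(C)C`, 42.2%
compound 2, `CCCCCCCCCCCCCC[C@H](OCOC)[C@H](CN1CCCCC1)NC(=O)OC(C)(C)C`, 19%

In a functional assay on A549 cells (Homo sapiens) for antiproliferative activity, read by sulforhodamine B assay, with a stated time of 48 h, tested at 10 uM (on this read-out lower numbers stand for less inhibition and higher numbers for more inhibition at the one concentration tested (going by the name of the read-out)), compound 2 stands lowest of the two numbers, with compound 1 the nearest. Among the compounds with values here, the one measured step, a number 23.2 percentage points lower from compound 1 to compound 2 (beyond the scatter), shows that changing the amine at this place can move the read-out. Compound 3, `CCCCCCCCCCCCCC[C@H](OCOC)[C@H](CN1CCN(C)CC1)NC(=O)OC(C)(C)C`, differs from compound 2 by 4-methylpiperazin-1-yl in place of piperidin-1-yl on a saturated chain carbon, two bonds along the chain from an amide-type nitrogen. Within the data shown here, no measured step exchanges these two groups, so the step 1>2 only indicates that the amine matters. Compound 3 is therefore expected to stay close to compound 2, with a number 1 percentage points higher from compound 2 to compound 3 (within the scatter) not beyond the scatter, and its estimated value is 20%, from 5% to 42%.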

Compound 3, a percentage reported as inhibition, at one concentration (the size of the read-out at that concentration, not a potency): 18.3%
The estimate for compound 3 lay 1.7 percentage points above the measured number, and the stated range covers the measured number.
By their numbers in this assay, from the lowest: compounds 3 and 2 (each within the scatter of the next); then compound 1.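

In this assay the step with 4-methylpiperazin-1-yl in place of piperidin-1-yl is a number 0.7 percentage points lower from compound 2 to compound 3 (within the scatter), so this exchange of one six-membered ring amine for the other does not separate the two compounds. With 4-methylpiperazin-1-yl in place of dibutylamino the step is a number 23.9 percentage points lower from compound 1 to compound 3 (beyond the scatter), which sets both ring amines apart from the open-chain dibutylamino of compound 1. No evidence here bears on why these numbers fall as they do. On these data alone, it remains open whether a morpholine ring or a diethylamino group at this place would read with the ring amines or with dibutylamino.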